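A few compounds are considered here, and "the series" means these few. Any claim that something is new, unique, unknown or untested is made for them only; others in the source may bear on it.

Three compounds of the shared core have been run in a functional assay on the whole organism (strain Wistar) for inhibition, with Rattus norvegicus as the target, read by paw edema, with stated times of 60 min and 1 h, at a dose of 100 mg/kg by the oral route; a lower number here means less inhibition, a higher number more inhibition at the dose given (going by the name of the read-out). Compound 1 `COc1cc2c(cc1OC)C(CC(=O)O)CC2` gives 18.8%. Compound 2 `CCN(CC)C(=O)CC1CCc2cc(OC)c(OC)cc21` gives 31.3%, and compound 3 `COc1cc2c(cc1OC)C(CC(=O)NC(C)(C)C)CC2` gives 31.3%. Compound 2 stands level with compound 3, the two together the highest of the three numbers, with compound 1 the furthest: a number 12.5 percentage points higher from compound 1 to compound 2 (beyond the scatter) and no change at the digits printed from compound 2 to compound 3 (within the scatter). Compound 4 `COc1cc2c(cc1OC)C(CC(=O)N1CCNCC1)CC2` remains unmeasured; it differs from compound 2 by piperazin-1-yl in place of diethylamino on a carbonyl carbon. Among the measured compounds shown here, the steps that bear on it are the changes at the carbonyl carbon, a number 12.5 percentage points higher from compound 1 to compound 3 (beyond the scatter) alongside the two above. Replacing one amine on that carbonyl by another left the number where it stood, so for compound 4 in this assay no step beyond the scatter is expected: a number 1.3 percentage points lower from compound 2 to compound 4 (within the scatter). The estimate for compound 4 is 30%, between 16% and 44%.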

Compound 4, a percentage reported as inhibition, in the whole organism at one dose (the size of the read-out at that dose, not a potency): 62.5%
Beside the measured number, compound 4's estimate is 32.5 percentage points below it; the whole stated range lies below it.
By their numbers in this assay, from the lowest: compound 1; then compounds 2 and 3 (each within the scatter of the next); then compound 4.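

In this assay the choice of amine on the carbonyl carbon does matter: piperazin-1-yl entering gives a number 31.2 percentage points higher from compound 2 to compound 4 (beyond the scatter) and a number 31.2 percentage points higher from compound 3 to compound 4 (beyond the scatter) even though diethylamino and (tert-butyl)amino had printed the same number. Against the hydroxy of the acid, the change gives a number 43.7 percentage points higher from compound 1 to compound 4 (beyond the scatter) and so goes well past the earlier amide steps. No measurement bears on why the number moves.

Open, on these data alone, is whether the ring or the hydrogen-bond donor carries the step: piperidin-1-yl or morpholin-4-yl on the same carbonyl carbon would hold the ring without that donor. Also open, as far as these compounds go, is whether 4-methylpiperazin-1-yl would keep the step.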